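Changing the sulfonyl ring on compound 2

A few compounds are considered here, and "the series" means these few. Any claim that something is new, unique, unknown or untested is made for them only; others in the source may bear on it.

Compound 1 `Cc1cc(C(F)(F)F)c2cccc(OCc3c(Cl)ccc(S(=O)(=O)N4CCC[C@H]4C(=O)O)c3Cl)c2n1` gives 13.3 mL/min/kg
Compound 2 `Cc1cc(C(F)(F)F)c2cccc(OCc3c(Cl)ccc(S(=O)(=O)N4CCCC4)c3Cl)c2n1` gives 967 mL/min/kg

In an ADME assay on microsomes (Mus musculus) for metabolic stability (a lower number here means slower removal, a higher number faster removal of the compound), compound 2 holds the higher of the two numbers, a very fast removal beside that of compound 1. The next compound, compound 3 `Cc1cc(C(F)(F)F)c2cccc(OCc3c(Cl)ccc(S(=O)(=O)N4CCCCC4)c3Cl)c2n1`, has not been measured. It differs from compound 2 by one change: piperidin-1-yl in place of pyrrolidin-1-yl on a sulfonyl sulfur.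

For the measured compounds named here, only one measured step touches this part of the molecule: a 73-fold higher number from compound 1 to compound 2 (1.86 log units; beyond the scatter) (hydrogen in place of carboxy on a saturated ring carbon). Going by the values given here, that step was large, but neither compound 2 nor compound 3 carries the carboxy, and no measured pair shows this ring swap. No step beyond the scatter is therefore expected in this assay, and no direction can be given. The expected step is a 1.0-fold lower number from compound 2 to compound 3 (0.01 log units; within the scatter) in size. For compound 3 the estimate is 950 mL/min/kg (expected range 450 mL/min/kg to 1900 mL/min/kg).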

Compound 3, clearance: 1000 mL/min/kg
Beside the measured number, compound 3's estimate is 1.1-fold (0.02 log units) below it; the range from low to high includes it.
By their numbers in this assay, from the lowest: compound 1; then compounds 2 and 3 (each within the scatter of the next).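

In this assay the size of this ring on the sulfonyl sulfur shows no effect beyond the scatter, since piperidin-1-yl in place of pyrrolidin-1-yl gives a 1.0-fold higher number from compound 2 to compound 3 (0.01 log units; within the scatter) and both compounds stay very fast. Piperidin-1-yl in place of 2-carboxypyrrolidin-1-yl gives a 75-fold higher number from compound 1 to compound 3 (1.88 log units; beyond the scatter), a step of much the same size as the one seen when only the carboxy is removed, so among these three compounds only the one carrying the carboxy has a low number. No independent measurement here explains either result.

Going by these compounds, whether a carboxylic acid on the piperidin-1-yl ring would bring the number down in the same way remains open. So does whether an amide in place of that acid, or an open diethylamino group on the sulfonyl sulfur, would read like the rings shown.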